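Replacing the anilide phenyl in compound 1

The compounds below may be only part of what the source reports. "The series", "measured", "known", "first", "only" and "open" are said of these compounds alone.

Compound 1 `CN(Cc1ccc(F)cc1)c1cc(C(=O)Nc2ccccc2)ncn1`: < 5000 nM (a limit)
Compound 2 `CN(Cc1cccnc1)c1cc(C(=O)Nc2ccccc2)ncn1`: 150000 nM

In a physicochemical assay for solubility, using the shake flask method, measured as kinetic solubility, with a stated time of 2 h, at pH 7.4 (on this read-out lower numbers stand for lower solubility and higher numbers for higher solubility), compound 1 is known only as a limit, < 5000 nM, and not as a number. Compound 3 `CN(Cc1ccc(F)cc1)c1cc(C(=O)Nc2ccn(C)n2)ncn1` carries 1-methyl-1H-pyrazol-3-yl in place of phenyl on an amide-type nitrogen. Among the compounds with values here, the one measured step that bears on this is an at least 30-fold higher number from compound 1 to compound 2 (1.47 log units; beyond the scatter), with pyridin-3-yl in place of 4-fluorophenyl on a saturated chain carbon bound to a nitrogen on an aromatic ring. That large step lies elsewhere in the molecule, so a rise of smaller size is expected here. The expected step is an at least 6.0-fold higher number from compound 1 to compound 3 (0.77 log units; beyond the scatter). The estimate for compound 3 is 30000 nM, within 5000 nM to 150000 nM.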

Compound 3, solubility: 90000 nM
For compound 3 the middle estimate is 3.0-fold (0.48 log units) below the measured one; measured number inside the range.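

In this assay, the amide-type nitrogen proves to be a second place where a single change moves the read-out: 1-methyl-1H-pyrazol-3-yl in place of phenyl gives an at least 18-fold higher number from compound 1 to compound 3 (1.25 log units; beyond the scatter). Until now, only the change on the saturated chain carbon had shown such a step. Compound 1 is held at a limit, so the full size of this step stays unknown: the limit of < 5000 nM in this assay, at which 1 of the 3 values shown sits.

Still open, going by these compounds, is whether the two changes add up when combined in one molecule. Also open, on these data alone, is whether an unmethylated pyrazole or a morpholine on the amide-type nitrogen would give a step of similar size.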